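The source may hold more compounds than are shown below. What is called first, only, known or untested is meant among the compounds shown, and "the series" means these compounds.

Of the compounds shown here, three have been measured so far. Compound 1 `CCOC(=O)c1cnn(-c2nc(-c3ccccc3F)c(C#N)c(=O)n2C)c1N` and compound 2 `CCOC(=O)c1cnn(-c2nc(-c3ccccc3Cl)c(C#N)c(=O)n2C)c1N` share one core and differ only in a single atom on the aromatic ring, while compound 3 `Cn1c(NN)nc(-c2ccccc2Cl)c(C#N)c1=O` carries a different core; the difference between the two cores is not broken down here.

In a functional assay, with a stated time of 20 min (a higher number here means a weaker inhibitor, a lower number a stronger inhibitor), compound 2 gives 78 ug/mL. Compound 1 gives 69 ug/mL in this assay. The change between them is fluoro in place of chloro on an aromatic carbon, and it made a step of a 1.1-fold lower number from compound 2 to compound 1 (0.05 log units; within the scatter). Compound 3 gives 58 ug/mL in this assay, which lies within the usual scatter of both other numbers, so the three measured values cannot be ranked against one another.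

Compound 4 `Cn1c(NN)nc(-c2ccccc2F)c(C#N)c1=O` has not yet been measured. It differs from compound 3 by fluoro in place of chloro on an aromatic carbon, the same change that separates compound 2 from compound 1, at a place described in the same words. Among the compounds with values here, the one measured example of this change moved the number only within the scatter, so the expectation is that compound 4 will stay close to compound 3 as well. On that basis the step from compound 3 to compound 4 in this assay is expected to be about a 1.1-fold lower number from compound 3 to compound 4 (0.04 log units; within the scatter). Compound 4 is therefore estimated to give about 53 ug/mL in this assay, with a plausible range from 30 ug/mL to 95 ug/mL, and this rests on a single prior example, so it is held loosely.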

Compound 4, half-maximal inhibitory concentration: 50 ug/mL
Compound 4: middle estimate off by 1.1-fold (0.03 log units), on the high side, and the stated range covers the measured number.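

Putting fluoro in place of chloro on the core of compound 3 gave a 1.2-fold lower number from compound 3 to compound 4 (0.06 log units; within the scatter), so in this assay this swap again leaves the number where it was, as far as the measurement can tell. Set beside the earlier example on the core of compound 1, the two steps agree: the same change on two cores in this assay, a 1.1-fold lower number (0.05 log units; within the scatter) from compound 2 to compound 1 and a 1.2-fold lower number (0.06 log units; within the scatter) from compound 3 to compound 4, 1.0-fold (0.01 log units) apart, within the scatter of two such steps

This shows that, for these two cores, the swap carries over in the plain sense that it produces no readable change on either one, but it does not show that fluoro and chloro have a real effect of a shared size, as both steps are small enough to be noise, and two cores cannot speak for every core in the series.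

On these data alone, only chloro and fluoro appear at this place on the aromatic ring, so it remains open whether a different group there, such as a methoxy group, an amine or a carboxylic acid, would move the number beyond the scatter on either core. As far as these compounds go, it also remains open whether a larger step, should one be found, would carry from one core to the other as faithfully as this small one seems to.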